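A second bromo on compound 2

The compounds below may be only part of what the source reports. "The series", "measured", "known", "first", "only" and "open" are said of these compounds alone.

Within the data shown here, in an ADME assay on HEK293 cells (Homo sapiens) for cytotoxicity, read by reporter gene assay and resazurin assay, with a stated time of 48 h (a higher number here means that more compound is tolerated, a lower number that less compound is tolerated), compound 2 `O=C(Nc1ccccc1)c1cc(Br)ccc1O` gives 35000 nM, the only exact number so far. For compound 1 `COc1c(Br)cc(Br)cc1C(=O)Nc1ccccc1`, the result is a limit, > 100000 nM. Compound 3 `O=C(Nc1ccccc1)c1cc(Br)cc(Br)c1O` has one change from compound 2: bromo in place of hydrogen on an aromatic carbon. The new bromo takes the place of a hydrogen on an aromatic carbon, ortho to a hydroxy group. Among the measured compounds shown here, no measured pair of compounds shows this change, so only a modest shift toward less compound being tolerated is expected, an estimated step of a 2.3-fold lower number from compound 2 to compound 3 (0.37 log units; beyond the scatter). The expected value for compound 3 is 15000 nM, with an estimated range of 4000 nM to 50000 nM.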

Compound 3, half-maximal cytotoxic concentration: 34000 nM
Beside the measured number, compound 3's estimate is 2.3-fold (0.36 log units) below it; measured number inside the range.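

With bromo in place of hydrogen on an aromatic carbon, ortho to a hydroxy group, this assay shows a 1.0-fold lower number from compound 2 to compound 3 (0.01 log units; within the scatter), so a bromo at this position brings no readable difference in tolerance. The free hydroxy group does separate two compounds, since hydrogen in place of methyl on the oxygen gives an at least 2.9-fold lower number from compound 1 to compound 3 (0.46 log units; beyond the scatter). The number for compound 1 is a limit, so this step is only a minimum: the limit of > 100000 nM in this assay, at which 1 of the 3 values shown sits.

From the compounds shown here alone, whether an amine or a carboxylic acid at this position would read differently remains open. So does the size of the methyl step in the absence of the second bromo.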